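Swapping the aryl amide of compound 1 for a benzothiophene

The compounds below may be only part of what the source reports. "The series", "measured", "known", "first", "only" and "open" are said of these compounds alone.

Compound 1 `COc1ccc(C(=O)NC[C@H]2c3[nH]c4ccccc4c3C[C@H]3[C@H]4c5[nH]c6ccccc6c5C[C@@H]([C@H](C#N)N23)N4C)cc1` is one of three close analogues measured in a functional assay on MCF7 cells (Homo sapiens) for cytotoxicity, read by MTT assay, with a stated time of 72 h; on this read-out lower numbers stand for stronger inhibition and higher numbers for weaker inhibition. There compound 1 gives 600 nM, the second highest of the three numbers. Compound 2 `CN1[C@@H]2c3[nH]c4ccccc4c3C[C@H]1[C@H](C#N)N1[C@@H](CNC(=O)c3ccc(F)cc3)c3[nH]c4ccccc4c3C[C@@H]21` gives 980 nM, and compound 3 `CCc1ccc(C(=O)NC[C@H]2c3[nH]c4ccccc4c3C[C@H]3[C@H]4c5[nH]c6ccccc6c5C[C@@H]([C@H](C#N)N23)N4C)cc1` gives 170 nM. The step of a 1.6-fold higher number from compound 1 to compound 2 (0.21 log units; within the scatter) is within the scatter, while a 3.5-fold lower number from compound 1 to compound 3 (0.55 log units; beyond the scatter) and a 5.8-fold lower number from compound 2 to compound 3 (0.76 log units; beyond the scatter) are both beyond it.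

Compound 4 `CN1[C@@H]2c3[nH]c4ccccc4c3C[C@H]1[C@H](C#N)N1[C@@H](CNC(=O)c3cc4ccccc4s3)c3[nH]c4ccccc4c3C[C@@H]21` differs from compound 1 by the change (1-benzothiophen-2-yl in place of 4-methoxyphenyl on a carbonyl carbon). Going by the values given here, none of the measured steps exchanges the whole ring: they only vary a single substituent on the 4-methoxyphenyl. Among the compounds with values here, the only guidance is that replacing methoxy by ethyl, which added carbon and removed the oxygen, gave the lower number in a 3.5-fold lower number from compound 1 to compound 3 (0.55 log units; beyond the scatter), and the entering 1-benzothiophen-2-yl likewise adds carbon while the oxygen leaves. A modest step towards a lower number is therefore expected, but with wide uncertainty. For compound 4 the estimate is 300 nM, in the range 100 nM to 900 nM, which means an expected step of a 2.0-fold lower number from compound 1 to compound 4 (0.30 log units; within the scatter).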

Compound 4, half-maximal inhibitory concentration: 3180 nM
Estimate against measurement, compound 4: 11-fold (1.03 log units) below, and the stated range ends below it.
By their numbers in this assay, from the lowest: compound 3; then compounds 1 and 2 (each within the scatter of the next); then compound 4.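

In this assay, exchanging the whole aryl ring on the carbonyl carbon gives a 5.3-fold higher number from compound 1 to compound 4 (0.72 log units; beyond the scatter), together with a 3.2-fold higher number from compound 2 to compound 4 (0.51 log units; beyond the scatter) and a 19-fold higher number from compound 3 to compound 4 (1.27 log units; beyond the scatter). The position is therefore not open to any larger carbon-rich ring: all three 4-substituted phenyl amides give lower numbers than the 1-benzothiophen-2-yl amide, and the link between adding carbon and a lower number seen with the 4-ethylphenyl of compound 3 does not carry over to compound 4. Nothing available explains this rise in the number.

The compounds shown leave open whether the sulfur or the fused ring goes with the change, since a thiophen-2-yl or naphthalen-2-yl amide would be needed to separate them. Going by these compounds, whether a longer chain, such as 4-propylphenyl, extends the result of compound 3 also remains open.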